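This account rests on a few compounds, and the source may have more. Where it says the series, first, only, none or still open, it means among the compounds named here.

Compound 2 `COc1ccc(-c2cc(=O)c3c(OC)cc(OC)cc3n2S(=O)(=O)c2cccc(Br)c2)cc1` carries a 3-bromophenyl group on the sulfonyl sulfur of the shared core. In a functional assay on HepG2 cells (Homo sapiens) for antiproliferative activity, with a stated time of 72 h (a higher number here means that more compound is needed for the effect, a lower number that less compound is needed), compound 2 reaches only an assay limit, > 58600 nM. Compound 1 `COc1ccc(-c2cc(=O)c3c(OC)cc(OC)cc3n2S(=O)(=O)c2ccc(Cl)cc2)cc1` bears a 4-chlorophenyl group at the same place. In this assay compound 1 likewise reaches only a limit, > 34400 nM. The step that the two limits leave unreadable from compound 1 to compound 2 stays unreadable, since both values sit at limits (the limit of > 34400 nM in this assay, at which 1 of the 2 values shown sits, (the limit of > 58600 nM in this assay, at which 1 of the 2 values shown sits)). Compound 3 `COc1ccc(-c2cc(=O)c3c(OC)cc(OC)cc3n2S(=O)(=O)c2ccc(Br)cc2)cc1` has not been measured; it differs from compound 2 by 4-bromophenyl in place of 3-bromophenyl on a sulfonyl sulfur. No readable step bears on this change, so compound 3 is expected near 60000 nM, between 15000 nM and 250000 nM, most likely again as a limit. This estimate implies an expected step that the limit leaves unreadable from compound 2 to compound 3.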

Compound 3, half-maximal effective concentration: 16300 nM
For compound 3 the middle estimate is 3.7-fold (0.57 log units) above the measured one, and the stated range covers the measured number.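

In this assay, among the compounds shown here, 4-bromophenyl in place of 3-bromophenyl on the sulfonyl sulfur gives the first readable change, an at least 3.5-fold lower number from compound 2 to compound 3 (0.55 log units; beyond the scatter), so the same atoms joined differently give a different result. Bromo in place of chloro on an aromatic carbon also registers, with an at least 2.1-fold lower number from compound 1 to compound 3 (0.32 log units; beyond the scatter). The full size of the first step is not known, since compound 2 reached only a limit: the limit of > 58600 nM in this assay, at which 1 of the 3 values shown sits.

Going by these compounds, the full size of the second step also stays open, since compound 1 reached only a limit: the limit of > 34400 nM in this assay, at which 1 of the 3 values shown sits. Whether an amine or a carboxylic acid in place of the bromo of compound 3 would lower the number further also stays open.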